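A few compounds are considered here, and "the series" means these few. Any claim that something is new, unique, unknown or untested is made for them only; others in the source may bear on it.

Series measured in a functional assay on MCF7 cells (Homo sapiens) for cytotoxicity, read by MTT assay, with a stated time of 96 h; a higher number here means a weaker inhibitor, a lower number a stronger inhibitor:

- compound 1 `Cc1cc2c(c(=O)o1)C(c1cccs1)C(C#N)=C(N)O2`: 15000 nM
- compound 2 `Cc1cc2c(c(=O)o1)C(c1c[nH]c3ccccc13)C(C#N)=C(N)O2`: 10000 nM
- compound 3 `Cc1cc2c(c(=O)o1)C(c1ccccc1)C(C#N)=C(N)O2`: 46000 nM

Compound 1 and compound 2 lie within the scatter of each other, so no order is read between them. Compound 3 stands apart from this pair, with the largest number of the three.

Next in view is compound 4 `Cc1cc2c(c(=O)o1)C(c1ccc(Cl)cc1)C(C#N)=C(N)O2`, which keeps the core of compound 1 and changes one group: 4-chlorophenyl in place of thiophen-2-yl on a saturated ring carbon. The group sits on a saturated ring carbon, next to the ring atom that bears a cyano group.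

For the measured compounds named here, one measured step bears on this change, the replacement of thiophen-2-yl by phenyl at the same place: a 3.1-fold higher number from compound 1 to compound 3 (0.49 log units; beyond the scatter). It is the closest available precedent, since the entering group of compound 4 is also a six-membered aromatic ring of carbon only. Going by the values given here, no measured compound carries a chlorine on that ring, so the data do not show how 4-chlorophenyl compares with phenyl. A modest step towards a higher number is therefore expected in this assay, of about the same size as the precedent or somewhat smaller.

The expected step is a 2.0-fold higher number from compound 1 to compound 4 (0.30 log units; within the scatter).

For compound 4 the estimated value is 30000 nM, with an expected range from 12000 nM to 70000 nM.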

Compound 4, half-maximal inhibitory concentration: 32000 nM
Compound 4: middle estimate off by 1.1-fold (0.03 log units), on the low side; measured number inside the range.
By their numbers in this assay, from the lowest: compounds 2 and 1 (each within the scatter of the next); then compounds 4 and 3 (each within the scatter of the next).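

In this assay, 4-chlorophenyl in place of thiophen-2-yl on the saturated ring carbon gives a 2.1-fold higher number from compound 1 to compound 4 (0.33 log units; beyond the scatter), so a second group with a six-membered aromatic ring of carbon only now stands on the higher side of compound 1 at this place, alongside the phenyl of compound 3. Chloro in place of hydrogen on the aromatic carbon gives a 1.4-fold lower number from compound 3 to compound 4 (0.16 log units; within the scatter), which lies within the scatter, so no order is read between these two compounds and this chlorine shows no measurable change in this assay. No measured evidence is available to explain either step.

As far as these compounds go, whether a methoxy, hydroxy or amino group on the same six-membered aromatic ring would separate from compound 3 remains open, as does the outcome with a saturated cyclohexyl ring or a longer alkyl chain on the saturated ring carbon. From the compounds shown here alone, the shared core also stays untested in these compounds, for instance a carboxylic acid or an amide in place of the cyano group.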